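Selenocyanate side chain shortened once more: compound 3

The source may report more compounds than this note shows. Statements on the series, on what has been measured and on what is new or still open speak of the compounds shown alone.

Compound 1 `COc1ccc(N(C)c2nc(C)nc3ccccc23)cc1C(=O)OCC[Se]C#N`: 951 nM
Compound 2 `COc1ccc(N(C)c2nc(C)nc3ccccc23)cc1C[Se]C#N`: 113 nM

Among the compounds with values here, in a functional assay on HCT-116 cells (Homo sapiens) for inhibition, read by MTT assay, with a stated time of 48 h (on this read-out higher numbers stand for weaker inhibition and lower numbers for stronger inhibition), compound 2 stands lowest of the two numbers measured; its only neighbour is compound 1, with an 8.4-fold lower number from compound 1 to compound 2 (0.93 log units; beyond the scatter). Compound 3 `COc1ccc(N(C)c2nc(C)nc3ccccc23)cc1[Se]C#N` is not yet measured. Its change from compound 2 is a group of 3 heavy atoms (1 carbon, 1 nitrogen, 1 selenium; no ring) in place of a group of 4 heavy atoms (2 carbon, 1 nitrogen, 1 selenium; no ring), on an aromatic carbon, the chain again made shorter. Within the data shown here, the one step that bears on this, an 8.4-fold lower number from compound 1 to compound 2 (0.93 log units; beyond the scatter), also shortened the chain and lowered the number, but that step removed far more. A step near the scatter is expected, perhaps slightly downward: a 1.1-fold higher number from compound 2 to compound 3 (0.03 log units; within the scatter). Compound 3 is therefore estimated at 120 nM, within 40 nM to 400 nM.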

Compound 3, half-maximal inhibitory concentration: 34 nM
Beside the measured number, compound 3's estimate is 3.5-fold (0.55 log units) above it, and the stated range ends above it.
By their numbers in this assay, from the lowest: compound 3; then compound 2; then compound 1.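

With the selenocyanate directly on the aromatic carbon, the series gives a 3.3-fold lower number from compound 2 to compound 3 (0.52 log units; beyond the scatter) in this assay, so even this small change, a group of 3 heavy atoms in place of a group of 4 heavy atoms, moves the number beyond the scatter. The whole shortening gives a 28-fold lower number from compound 1 to compound 3 (1.45 log units; beyond the scatter) and the numbers follow chain length in all three compounds, with none going against this order. On these data alone, how an amine or a carboxylic acid on this aromatic carbon would compare remains open. No measurement here explains the drop.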